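The compounds below may be only part of what the source reports. "The series", "measured", "known", "first", "only" and "open" are said of these compounds alone.

Compound 1 `Cc1ccc(NC2=CC(=O)c3nc4n(c3C2=O)[C@H]2OC[C@@H](O)[C@H]2OC4)cc1` stands lowest of the two numbers in a functional assay on HeLa cells (Homo sapiens) for inhibition, read by sulforhodamine B assay (on this read-out lower numbers stand for stronger inhibition and higher numbers for weaker inhibition), where compound 1 gives 3860 nM. Its nearest neighbour is compound 2 `CCCc1ccc(NC2=CC(=O)c3c(nc4n3[C@H]3OC[C@@H](O)[C@H]3OC4)C2=O)cc1`, which in this assay gives 6030 nM, a gap that lies within the scatter, so no order between the two can be claimed. Compound 3 `O=C1C(NC2CC2)=CC(=O)c2c1nc1n2[C@H]2OC[C@@H](O)[C@H]2OC1` reaches only a limit in this assay, > 16000 nM, and not a number. Among the compounds with values here, the one measured step, an at least 2.6-fold higher number from compound 2 to compound 3 (0.42 log units; beyond the scatter), shows that taking the aromatic ring off the amine nitrogen weakens inhibition, the size of that step being bounded only because the limit of > 16000 nM in this assay, at which 1 of the 3 values shown sits, caps it.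

Compound 4 `O=C1C=C(N2CCCCC2)C(=O)c2c1nc1n2[C@H]2OC[C@@H](O)[C@H]2OC1` has not yet been measured. Its change from compound 1 is piperidin-1-yl in place of (4-methylphenyl)amino on a double-bonded ring carbon. Like the step from compound 2 to compound 3, the change removes the six-membered aromatic ring, and it also removes the hydrogen-bond donor; the entering piperidin-1-yl is a non-aromatic ring carrying no donor. The step from compound 2 to compound 3 therefore bears on it and suggests weaker inhibition, at least of modest size and possibly reaching the limit again. Compound 4 is expected to give about 14000 nM in this assay, in the range 6000 nM to 40000 nM, which is estimated as a 3.6-fold higher number from compound 1 to compound 4 (0.56 log units; beyond the scatter).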

Compound 4, half-maximal inhibitory concentration: > 16000 nM
Compound 4: only a limit was reported (the forecaster's own chance of this, stated with the estimate: 45%); middle value at least 1.1-fold (0.05 log units) away from the limit.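

Piperidin-1-yl in place of (4-methylphenyl)amino on a double-bonded ring carbon gives an at least 4.1-fold higher number from compound 1 to compound 4 (0.61 log units; beyond the scatter) in this assay. Unlike the cyclopropyl of compound 3, the entering group here is a six-membered ring like the one that leaves, though non-aromatic, and it carries no hydrogen-bond donor, so a ring of that size on this carbon is not enough to keep the inhibition seen with compound 1. Across the compounds shown, the two with an aromatic ring on the nitrogen give numbers and the two without one do not, and none goes against this pattern, though it rests on very few compounds.

The true size of this step stays open, and compound 4 cannot be placed against compound 3, because each of them gives only a limit and not a number: the limit of > 16000 nM in this assay, at which 2 of the 4 values shown sit.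

Nor do the compounds shown separate the loss of the aromatic ring from the loss of the donor, which a cyclohexylamino group or a (4-methylphenyl)(methyl)amino group on the same carbon would bear on.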